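A few compounds are considered here, and "the series" means these few. Any claim that something is new, unique, unknown or untested is made for them only; others in the source may bear on it.

In a functional assay on DU-145 cells (Homo sapiens) for cytotoxicity, read by sulforhodamine B assay, with a stated time of 48 h (a higher number here means a weaker inhibitor of growth, a lower number a stronger inhibitor of growth), compound 1 `N#Cc1ccc(Nc2nc(Oc3ccnc4ccccc34)nc(N3CCN(c4ccc(F)cc4)CC3)n2)cc1C(F)(F)F` gives only a limit of > 100000 nM. Going by the values given here, compound 2 `CCN1CCN(c2nc(Nc3ccc(C#N)c(C(F)(F)F)c3)nc(Oc3ccnc4ccccc34)n2)CC1` gives 86600 nM, the only true number so far, so there is little to rank it against. Compound 3 `CC(C)N1CCN(c2nc(Nc3ccc(C#N)c(C(F)(F)F)c3)nc(Oc3ccnc4ccccc34)n2)CC1` turns the 4-ethylpiperazin-1-yl of compound 2 into 4-isopropylpiperazin-1-yl: methyl in place of hydrogen on a saturated chain carbon bound to an amine nitrogen in a ring and a saturated chain carbon, with methyl in place of hydrogen on a saturated chain carbon bound to an amine nitrogen in a ring and a saturated chain carbon. Among the compounds with values here, one measured step bears on this, namely an at least 1.1-fold lower number from compound 1 to compound 2 (0.06 log units; that floor lies within the scatter), which put ethyl in place of 4-fluorophenyl on an amine nitrogen in a ring. As far as these compounds go, its true size stays open because of the limit of > 100000 nM in this assay, at which 1 of the 2 values shown sits. Adding methyl to that ethyl is a smaller change, so no step beyond the scatter is expected, and the estimate is a 1.2-fold lower number from compound 2 to compound 3 (0.06 log units; within the scatter). For compound 3 the expected value is 75000 nM, with an estimated range from 35000 nM to 100000 nM.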

Compound 3, concentration for 50% growth inhibition: > 100000 nM
Compound 3: only a limit was reported (the forecaster's own chance of this, stated with the estimate: 30%); at least 1.3-fold (0.12 log units) between middle value and limit.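

In this assay, changing 4-ethylpiperazin-1-yl to 4-isopropylpiperazin-1-yl gives an at least 1.1-fold higher number from compound 2 to compound 3 (0.06 log units; that floor lies within the scatter), so the added methyl brings no visible gain in growth inhibition. As far as these compounds go, compound 3 gives only a limit, > 100000 nM, so the true size of this step remains unknown. The step between compound 1 and compound 3 cannot be read, because both values are limits: the limit of > 100000 nM in this assay, at which 2 of the 3 values shown sit.

The compounds shown leave open whether a smaller group, such as methyl, would give a clearly lower number than compound 2 when placed on the same amine nitrogen in a ring. They also leave open whether a chain ending in a hydroxyl group or a carboxylic acid there would change growth inhibition by more than the usual scatter.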